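This account rests on a few compounds, and the source may have more. Where it says the series, first, only, none or still open, it means among the compounds named here.

Values in a functional assay on HT-29 cells (Homo sapiens) for inhibition, read by MTT assay, with a stated time of 48 h (on this read-out lower numbers stand for stronger inhibition and higher numbers for weaker inhibition), for the measured compounds:
- compound 1 `COc1ccc(-n2c(SC)nnc2-c2cc(OC)c(OC)c(OC)c2)cc1` gives > 60000 nM (a limit)
- compound 2 `COc1ccc(-n2c(SCC(=O)c3ccc(F)cc3)nnc2-c2cc(OC)c(OC)c(OC)c2)cc1` gives 42500 nM as a number
- compound 3 `COc1cc(-c2nnc(SC)n2-c2ccc(N(C)C)cc2)cc(OC)c1OC` gives > 60000 nM (a limit)

Compound 3 sits at the limit of > 60000 nM in this assay, at which 2 of the 3 values shown sit, and so offers no number to start from. The change to compound 4 `COc1cc(-c2nnc(SCc3ccc(C)cc3)n2-c2ccc(N(C)C)cc2)cc(OC)c1OC` reads 4-methylphenyl in place of hydrogen on a saturated chain carbon bound to a sulfur and amounts to methylsulfanyl going to (4-methylbenzyl)sulfanyl.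

The nearest measured step is an at least 1.4-fold lower number from compound 1 to compound 2 (0.14 log units; that floor lies within the scatter) and it also replaces a hydrogen on that chain carbon, yet its floor stays within the scatter. For the measured compounds named here, compound 2 at 42500 nM is the only number in the set, and it carries a carbonyl that compound 4 lacks. For dimethylamino in place of methoxy there is only a step that the two limits leave unreadable from compound 1 to compound 3 and this adds no size.

A modest move towards stronger inhibition in this assay is therefore expected, resting on that single pair. The expected step is an at least 2.4-fold lower number from compound 3 to compound 4 (0.38 log units; beyond the scatter) and it could prove larger or vanish within the scatter. Compound 4 is estimated at 25000 nM with an expected range from 4000 nM to 60000 nM and a real chance of another reading at the limit.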

Compound 4, half-maximal inhibitory concentration: 27500 nM
The estimate for compound 4 lay 1.1-fold (0.04 log units) below the measured number, and the stated range covers the measured number.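

In this assay, a change on the saturated chain carbon bound to a sulfur now gives a step whose floor lies beyond the scatter: an at least 2.1-fold lower number from compound 3 to compound 4 (0.33 log units; beyond the scatter). The earlier step at that carbon, an at least 1.4-fold lower number from compound 1 to compound 2 (0.14 log units; that floor lies within the scatter), had a floor still within the scatter and brought in a carbonyl, whereas 4-methylphenyl carries none, so in the dimethylamino pair a readable move to a lower number at this place does not require a carbonyl in the added group. The true size stays unknown, since compound 3 stands at a limit and the step is only a floor: the limit of > 60000 nM in this assay, at which 2 of the 4 values shown sit.

The step between the methoxy and dimethylamino compounds with the methylsulfanyl group cannot be read, so the compounds shown do not tell whether exchanging methoxy for dimethylamino alters the result of substitution at this carbon. Also open, on these data alone, is whether an aromatic ring is needed on this chain carbon at all, a question that a longer chain such as butyl, an amine or a carboxylic acid in place of 4-methylphenyl would address.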